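Swapping a Fluorophenyl for a Thiophene on a Shared Core

A few compounds are considered here, and "the series" means these few. Any claim that something is new, unique, unknown or untested is made for them only; others in the source may bear on it.

Measured compounds:
Compound 1 `O=Cc1ccc(-c2cn3ccnc3c(-c3ccc4ncn(C5CCCCC5)c4c3)n2)cc1`: 46.9%
Compound 2 `Fc1ccccc1-c1cn2ccnc2c(-c2ccc3ncn(C4CCCCC4)c3c2)n1`: 5.77%

In a functional assay on LOX IMVI cells (Homo sapiens) for inhibition, read by sulforhodamine B assay, with a stated time of 48 h, tested at 10 uM (a lower number here means less inhibition, a higher number more inhibition at the concentration tested (going by the name of the read-out)), compound 2 gives 5.77%, the lower of the two numbers; compound 1 gives 46.9%. Compound 3 `c1csc(-c2cn3ccnc3c(-c3ccc4ncn(C5CCCCC5)c4c3)n2)c1` differs from compound 2 by thiophen-2-yl in place of 2-fluorophenyl on an aromatic carbon. Among the measured compounds shown here, the only measured step, a number 41.1 percentage points lower from compound 1 to compound 2 (beyond the scatter), concerns a different exchange, so no measured step bears directly on this one; both known values suggest a modest number. Compound 3 is therefore expected to give about 15%, between 0% and 45%. The expected step is a number 9.2 percentage points higher from compound 2 to compound 3 (within the scatter), within the scatter.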

Compound 3, a percentage reported as inhibition, at one concentration (the size of the read-out at that concentration, not a potency): 1.07%
Estimate against measurement, compound 3: 13.9 percentage points above, within the range that was stated.
By their numbers in this assay, from the lowest: compounds 3 and 2 (each within the scatter of the next); then compound 1.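

At this aromatic carbon of the shared core, swapping one ring for another changes little: this assay shows a number 4.7 percentage points lower from compound 2 to compound 3 (within the scatter), so thiophen-2-yl and 2-fluorophenyl read alike. Against 4-formylphenyl the picture differs, with a number 45.8 percentage points lower from compound 1 to compound 3 (beyond the scatter), which leaves compound 1 alone at the higher number among these three. Nothing measured here explains this difference. Still open, as far as these compounds go, is whether the formyl group itself accounts for the higher number, or whether an amine or a carboxylic acid on that phenyl ring would give a similar reading.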